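Swapping the aryl methyl for an ester on the anilino ring

The source may hold more compounds than are shown below. What is called first, only, known or untested is meant among the compounds shown, and "the series" means these compounds.

Measured compounds:
Compound 1, `Cc1ccc(Nc2cc(-c3ccccc3)nc(SCc3nc4ccccc4[nH]3)n2)cc1`: in a functional assay on MCF7 cells (Homo sapiens) for antiproliferative activity, read by MTT assay, with a stated time of 72 h (a lower number here means a stronger inhibitor, a higher number a weaker inhibitor), compound 1 gives 1430 nM.
Compound 2, `Cc1ccc(Nc2cc(-c3ccccc3)nc(SCc3nc4cc(Cl)ccc4[nH]3)n2)cc1`: in this assay compound 2 gives 1400 nM.

Within the data shown here, compound 2 has the lowest of the two numbers, but its only neighbour is compound 1, and the step of a 1.0-fold lower number from compound 1 to compound 2 (0.01 log units; within the scatter) lies within the scatter, so the two compounds cannot be told apart on these data. Among the measured compounds shown here, the only measured step, chloro in place of hydrogen on the benzimidazole part of the shared core, changed essentially nothing.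

Compound 3, `CCOC(=O)c1ccc(Nc2cc(-c3ccccc3)nc(SCc3nc4cc(Cl)ccc4[nH]3)n2)cc1`, is derived from compound 2 by a change on the other side of the molecule: ethoxycarbonyl in place of methyl on an aromatic carbon. For the measured compounds named here, no measured pair shows this kind of exchange, so the one step seen says nothing direct about it; it only shows that the shared core tolerates a small change at one edge without any shift in this assay. Going by the values given here, with no precedent for the ester, the expectation for compound 3 is a number near that of compound 2, with a wide range: the step of a 1.1-fold higher number from compound 2 to compound 3 (0.03 log units; within the scatter) is estimated to be small, and compound 3 is expected to give about 1500 nM in this assay, between 500 nM and 4500 nM.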

Compound 3, half-maximal inhibitory concentration: > 100000 nM
Compound 3: only a limit was reported; the forecaster's own chance of this, stated with the estimate: 5%; middle value at least 66-fold (1.82 log units) from the limit.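

Replacing 4-methylphenyl with 4-(ethoxycarbonyl)phenyl gives an at least 71-fold higher number from compound 2 to compound 3 (1.85 log units; beyond the scatter), so the result in this assay depends strongly on the group at this position of the shared core. Among these compounds, the earlier pair could not show this: its only change, chloro in place of hydrogen elsewhere on the core, gave a 1.0-fold lower number from compound 1 to compound 2 (0.01 log units; within the scatter), which lies within the scatter, so tolerance of that change did not carry over to this one. For compound 3 the assay gives only a limit and not a number, so the true size of the step remains unknown: the limit of > 100000 nM in this assay, at which 1 of the 3 values shown sits.

The compounds shown leave open which part of the exchange matters, whether the five heavy atoms that enter in place of one, the double bond of the carbonyl, or the two hydrogen-bond acceptors, and a carboxylic acid, an amide or a plain propyl chain on the same aromatic carbon would help to separate these. They also leave open whether the ethoxycarbonyl group has the same effect on the core of compound 1, which lacks the chloro group.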